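Isopropyl in place of hydroxy on the amino acid residue

A few compounds are considered here, and "the series" means these few. Any claim that something is new, unique, unknown or untested is made for them only; others in the source may bear on it.

Compound 2 `COC(=O)[C@@H](CO)NC(=O)Cn1cc(C2=C(c3c[nH]c4ccccc34)C(=O)N(C)C2=O)c2ccccc21` and compound 1 `COC(=O)[C@H](NC(=O)Cn1cc(C2=C(c3c[nH]c4ccccc34)C(=O)N(C)C2=O)c2ccccc21)[C@@H](C)O` differ in one place. In a functional assay on HCT-8 cells (Homo sapiens) for cytotoxicity, read by MTT assay, with a stated time of 24 h (a lower number here means a stronger inhibitor, a higher number a weaker inhibitor), compound 1 gives 23400 nM and compound 2 gives 22900 nM; the step of a 1.0-fold lower number from compound 1 to compound 2 (0.01 log units; within the scatter) leaves the two within the scatter, so compound 2 stands level with compound 1 among the two numbers shown. Compound 3 `COC(=O)[C@@H](CC(C)C)NC(=O)Cn1cc(C2=C(c3c[nH]c4ccccc34)C(=O)N(C)C2=O)c2ccccc21` carries isopropyl in place of hydroxy on a saturated chain carbon, two bonds along the chain from an amide-type nitrogen and a carbonyl carbon. Going by the values given here, the only measured step, from compound 1 to compound 2, was flat, so no step beyond the scatter is expected in this assay. Compound 3 is therefore estimated at 22000 nM, between 8000 nM and 60000 nM, a step of a 1.0-fold lower number from compound 2 to compound 3 (0.02 log units; within the scatter).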

Compound 3, half-maximal inhibitory concentration: 37800 nM
For compound 3 the middle estimate is 1.7-fold (0.24 log units) below the measured one; low and high end bracket the measured number.
By their numbers in this assay, from the lowest: compounds 2, 1 and 3 (each within the scatter of the next).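

In this assay isobutyl in place of hydroxymethyl gives a 1.7-fold higher number from compound 2 to compound 3 (0.22 log units; within the scatter) and isobutyl in place of 1-hydroxyethyl gives a 1.6-fold higher number from compound 1 to compound 3 (0.21 log units; within the scatter) so a side chain without a hydroxy group, with no hydrogen-bond donor or acceptor, stands level with both hydroxy-bearing chains at this position. Across these compounds, the hydroxy group is not required to keep the number at this level. Nothing shown here offers an explanation for this. Still open, from the compounds shown here alone, is whether an amine, a carboxylic acid or a phenyl ring on this side chain would move the number beyond the scatter.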